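The source may report more compounds than this note shows. Statements on the series, on what has been measured and on what is new or still open speak of the compounds shown alone.

Compound 1 `Cc1cc(NC(=O)Nc2cccc(C(N)=O)c2)c2ccccc2n1`: > 25000 nM
Compound 2 `Cc1cc(NC(=O)Nc2cccc(F)c2)c2ccccc2n1`: > 25000 nM
Compound 3 `Cc1cc(NC(=O)Nc2cc(F)cc(F)c2)c2ccccc2n1`: > 25000 nM

In an ADME assay on HepG2 cells (Homo sapiens) for cytotoxicity, with a stated time of 72 h (on this read-out lower numbers stand for an effect already at smaller amounts and higher numbers for an effect only at larger amounts of compound), compound 2 gives only a limit, > 25000 nM, not a number. The same holds for compound 1, whose value > 25000 nM is a limit, and for compound 3, whose value > 25000 nM is a limit as well. Compound 2 therefore cannot be placed against the other two: all three sit at the limit of > 25000 nM in this assay, at which 3 of the 3 values shown sit, and the two steps that touch compound 2, a step that the two limits leave unreadable from compound 1 to compound 2 and a step that the two limits leave unreadable from compound 2 to compound 3, leave their size unreadable.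

The next compound, compound 4 `Cc1cc(NC(=O)Nc2ccc(N)cc2)c2ccccc2n1`, differs from compound 2 by 4-aminophenyl in place of 3-fluorophenyl on an amide-type nitrogen. Both measured steps around compound 2 bear on this change only in that neither produced a readable number, so no direction or size can be taken from them. Compound 4 is expected to show the same behaviour, with a step that the limit leaves unreadable from compound 2 to compound 4 that is not expected to exceed the scatter. The estimate for compound 4 is 30000 nM, with a range from 15000 nM to 60000 nM.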

Compound 4, half-maximal effective concentration: > 25000 nM
Compound 4 gave a limit, no number; the forecaster's own chance of this, stated with the estimate: 85%; the middle value is on the limit's open side.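

In this assay compound 4 gives > 25000 nM as a limit and not a number. Within the data shown here, compound 2 also gives only a limit, so no step from compound 2 to compound 4 can be read. The compounds shown leave open at what concentration, if any, a cytotoxic effect would appear: the limit of > 25000 nM in this assay, at which 4 of the 4 values shown sit.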